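Half-life notes: from compound 2 to compound 3

The source may hold more compounds than are shown below. What is called first, only, known or untested is meant among the compounds shown, and "the series" means these compounds.

Among the compounds with values here, in an ADME assay, at pH 5 (on this read-out lower numbers stand for a shorter-lived compound and higher numbers for a longer-lived compound), compound 2 (`COc1ccnc(C[S+]([O-])c2nc3cc(OC(F)(F)C(F)F)ccc3[nH]2)c1C`) gives 0.3 h, the lower of the two numbers so far. Within the data shown here, the only comparison, compound 1 (`COc1cnc(C[S+]([O-])c2nc3cc(OC(F)(F)C(F)F)ccc3[nH]2)cc1OC`), gives 2.9 h, a gap beyond the usual scatter. Compound 3 (`COc1cc(C[S+]([O-])c2nc3cc(OC(F)(F)C(F)F)ccc3[nH]2)ncc1C`) has the same atoms as compound 2, joined differently: 4-methoxy-5-methylpyridin-2-yl in place of 4-methoxy-3-methylpyridin-2-yl on a saturated chain carbon bound to a sulfur. It carries 4-methoxy-5-methylpyridin-2-yl in place of 4-methoxy-3-methylpyridin-2-yl on a saturated chain carbon bound to a sulfur. Among the measured compounds shown here, no single-place step has been measured, so the expectation rests on two values only: compound 2 at 0.3 h and compound 1 at 2.9 h. A result inside that span is expected, with a longer life than compound 2. The expected change is a 3.3-fold higher number from compound 2 to compound 3 (0.52 log units; beyond the scatter), an upward step estimated to lie beyond the scatter. Compound 3 is estimated at 1 h, with an expected range of 0.4 h to 2.5 h.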

Compound 3, half-life: 0.2 h
Beside the measured number, compound 3's estimate is 5.0-fold (0.70 log units) above it; the whole stated range lies above it.
By their numbers in this assay, from the lowest: compounds 3 and 2 (each within the scatter of the next); then compound 1.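

In this assay, moving the methyl group so that 4-methoxy-5-methylpyridin-2-yl stands in place of 4-methoxy-3-methylpyridin-2-yl on a saturated chain carbon bound to a sulfur gives a 1.5-fold lower number from compound 2 to compound 3 (0.18 log units; within the scatter) and so does not separate this pair on this read-out. Methyl in place of methoxy on an aromatic carbon gives a 15-fold lower number from compound 1 to compound 3 (1.16 log units; beyond the scatter), the first large single-place step in the series, so the half-life of this pair depends strongly on that one exchange. No supporting measurement accounts for either step.

From the compounds shown here alone, whether an ethoxy group, an amine or a chlorine atom on that aromatic carbon would fall nearer compound 1 or compound 3 remains open. Also open, going by these compounds, is whether the methoxy-to-methyl step keeps its size when the tetrafluoroethoxy group on the shared core is replaced by a plain ethoxy group.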